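Fluoro for hydrogen on the dimethylphenyl ring: compound 4

This account rests on a few compounds, and the source may have more. Where it says the series, first, only, none or still open, it means among the compounds named here.

Compound 1 `O=C(O)C[C@H](O)C[C@H](O)CCn1c(C(F)(F)F)nc(-c2ccccc2)c1-c1ccc(F)cc1` gives 31 nM in an assay on microsomes from liver for inhibition of 3-hydroxy-3-methylglutaryl-coenzyme A reductase (Rattus norvegicus); a higher number here means a weaker inhibitor, a lower number a stronger inhibitor. Compound 2 `O=C(O)C[C@H](O)C[C@H](O)CCn1c(C(F)(F)F)nc(-c2ccc(F)cc2)c1-c1ccc(F)cc1` carries fluoro in place of hydrogen on an aromatic carbon and gives 38 nM in this assay; the step is a 1.2-fold higher number from compound 1 to compound 2 (0.09 log units; within the scatter). Compound 3 `Cc1cc(C)cc(-c2c(-c3ccc(F)cc3)nc(C(F)(F)F)n2CC[C@@H](O)C[C@@H](O)CC(=O)O)c1` gives 38 nM, and no change at the digits printed from compound 2 to compound 3 (within the scatter). The difference between the core of compound 1 and the core of compound 3 is not broken down here. Compound 4 `Cc1cc(-c2c(-c3ccc(F)cc3)nc(C(F)(F)F)n2CC[C@@H](O)C[C@@H](O)CC(=O)O)cc(C)c1F`, not yet measured, carries fluoro in place of hydrogen on an aromatic carbon. Within the data shown here, this is the same kind of change as the one from compound 1 to compound 2, not the same: in compound 4 the aromatic carbon is ortho to two methyl groups (1 heavy atom each), which the earlier place lacks. Because a 1.2-fold higher number from compound 1 to compound 2 (0.09 log units; within the scatter) stayed within the scatter, compound 4 is expected to show a 1.1-fold higher number from compound 3 to compound 4 (0.04 log units; within the scatter) in this assay. The estimate for compound 4 is 42 nM, between 22 nM and 80 nM.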

Compound 4, half-maximal inhibitory concentration: 31 nM
Beside the measured number, compound 4's estimate is 1.4-fold (0.13 log units) above it, within the range that was stated.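

In this assay, fluoro in place of hydrogen on an aromatic carbon reads alike on the two cores shown: the same change on two cores in this assay, a 1.2-fold higher number (0.09 log units; within the scatter) from compound 1 to compound 2 and a 1.2-fold lower number (0.09 log units; within the scatter) from compound 3 to compound 4, 1.5-fold (0.18 log units) apart, within the scatter of two such steps. At the aromatic carbon ortho to two methyl groups, the step is a 1.2-fold lower number from compound 3 to compound 4 (0.09 log units; within the scatter), and replacing 4-fluorophenyl with 4-fluoro-3,5-dimethylphenyl gives a 1.2-fold lower number from compound 2 to compound 4 (0.09 log units; within the scatter). The change therefore carries across these two cores without a step beyond the scatter, but this shows neither a gain nor a loss on either core, and it says nothing about any further core.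

Still open, going by these compounds, is whether chloro, methoxy or an amine at that place would give a step beyond the scatter. On these data alone, replacing the trifluoromethyl group is also open.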